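From 4-Chlorophenyl to 4-Cyanophenyl: an Expected Small Step

The compounds below may be only part of what the source reports. "The series", "measured", "known", "first", "only" and "open" are said of these compounds alone.

Compound 1 `CCOC(=O)c1ccc(NC(=O)CCc2cccc3c2B(O)OC3)cc1` reaches only a limit, > 100000 nM, in a functional assay on MDA-MB-231 cells (Homo sapiens) for antiproliferative activity, read by MTT assay, with a stated time of 72 h; on this read-out higher numbers stand for weaker inhibition and lower numbers for stronger inhibition. Compound 2 `C#Cc1cccc(NC(=O)CCc2cccc3c2B(O)OC3)c1` gives 1600 nM there, and compound 3 `O=C(CCc1cccc2c1B(O)OC2)Nc1cccc(-c2ccc(Cl)cc2)c1` gives 260 nM. The step of a 6.2-fold lower number from compound 2 to compound 3 (0.79 log units; beyond the scatter) lies beyond the scatter. Among the two numbers known, compound 3 stands lowest, with compound 2 nearest. Compound 4 `N#Cc1ccc(-c2cccc(NC(=O)CCc3cccc4c3B(O)OC4)c2)cc1` is not yet measured; it differs from compound 3 by cyano in place of chloro on an aromatic carbon. Among the measured compounds shown here, the only measured step on an aromatic carbon, a 6.2-fold lower number from compound 2 to compound 3 (0.79 log units; beyond the scatter), swaps a whole group rather than the substituent of the 4-chlorophenyl, so it fixes no direction for this change. The account therefore expects a step within the scatter, at most a mild rise, a 1.5-fold higher number from compound 3 to compound 4 (0.19 log units; within the scatter). Compound 4 is estimated at 400 nM, between 150 nM and 1200 nM.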

Compound 4, half-maximal inhibitory concentration: 380 nM
Estimate against measurement, compound 4: 1.1-fold (0.02 log units) above; the measured number falls inside the stated range.
By their numbers in this assay, from the lowest: compounds 3 and 4 (each within the scatter of the next); then compound 2. At a limit, above all of these: compound 1.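

In this assay, cyano and chloro para to a large group could not be told apart, with a 1.5-fold higher number from compound 3 to compound 4 (0.16 log units; within the scatter) as the step between them. The advantage of an aryl group over ethynyl on the aromatic carbon therefore holds for a second substituent, with a 4.2-fold lower number from compound 2 to compound 4 (0.62 log units; beyond the scatter) as a further step beyond the scatter. Nothing measured bears on a cause for either step. As far as these compounds go, whether this tolerance extends to an amine or a carboxylic acid at the same place remains open. The compounds shown also leave open how a bare phenyl would compare.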